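The source may report more compounds than this note shows. Statements on the series, on what has been measured and on what is new or still open speak of the compounds shown alone.

Of the compounds shown here, three built on one shared core have been tested in an ADME assay on Huh-7 cells (Homo sapiens) for cytotoxicity; on this read-out higher numbers stand for lower toxicity in this test and lower numbers for higher toxicity in this test. Compound 1 `N#Cc1cccc(C(=O)NC(=S)N2CCc3c(OCCCCCOc4ccc(Cl)cc4)cccc32)c1` gives 9750 nM in this assay. For compound 2 `O=C(CCc1ccccc1)NC(=S)N1CCc2c(OCCCCCOc3ccc(Cl)cc3)cccc21`, this assay reports only a limit, > 50000 nM. For compound 3 `O=C(NC(=S)N1CCc2c(OCCCCCOc3ccc(Cl)cc3)cccc21)C1CCCC1`, this assay likewise reports only a limit, > 50000 nM. The readable steps are an at least 5.1-fold higher number from compound 1 to compound 2 (0.70 log units; beyond the scatter) and an at least 5.1-fold higher number from compound 1 to compound 3 (0.70 log units; beyond the scatter); both end at the limit of > 50000 nM in this assay, at which 2 of the 3 values shown sit, so their true size is not known. Between the two limits, a step that the two limits leave unreadable from compound 2 to compound 3. Compound 3 therefore stands at the limit of > 50000 nM in this assay, at which 2 of the 3 values shown sit, with no exact number of its own.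

Compound 4 `S=C(NC(=S)N1CCc2c(OCCCCCOc3ccc(Cl)cc3)cccc21)Oc1ccccc1` differs from compound 3 in one place: a group of 9 heavy atoms (7 carbon, 1 oxygen, 1 sulfur; one six-membered aromatic ring of carbon only) in place of a group of 7 heavy atoms (6 carbon, 1 oxygen; one five-membered non-aromatic ring of carbon only), on an amide-type nitrogen. Going by the values given here, none of the measured steps touches this change, since each of them swaps only the group on the carbonyl carbon, whereas here the whole cyclopentylcarbonyl group leaves. The two measured steps do show that compound 1, the only compound with a six-membered aromatic ring in this position, gives the lowest number shown, 9750 nM. Compound 4 is therefore expected to give roughly 30000 nM, in a range from 8000 nM to 60000 nM, which would mean an estimated step of an at least 1.6-fold lower number from compound 3 to compound 4 (0.22 log units; that floor lies within the scatter).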

Compound 4, half-maximal cytotoxic concentration: > 50000 nM
Compound 4 gave a limit, no number (the forecaster's own chance of this, stated with the estimate: 40%); middle value at least 1.6-fold (0.22 log units) away from the limit.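

In this assay compound 4 reports only a limit, > 50000 nM. Its new group carries a six-membered aromatic ring of carbon only, as the group in compound 1 does, yet the step is an at least 5.1-fold higher number from compound 1 to compound 4 (0.70 log units; beyond the scatter), so such a ring on this amide-type nitrogen does not by itself go with a low number. The steps from compound 2 and from compound 3 to compound 4 cannot be read, because all three compounds sit at one ceiling: the limit of > 50000 nM in this assay, at which 3 of the 4 values shown sit.

Still open, on these data alone, is whether the lower number of compound 1 goes with its nitrile or with the rest of its group, which a plain benzoyl group or a carboxylic acid in place of the nitrile could separate. As far as these compounds go, how far compound 2, compound 3 and compound 4 differ from one another also stays unknown.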